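The source may hold more compounds than are shown below. What is called first, only, known or untested is meant among the compounds shown, and "the series" means these compounds.

Three compounds measured in an ADME assay on MT4 cells (Homo sapiens) for cytotoxicity, read by MTT assay, with a stated time of 4 days (a lower number here means that less compound is tolerated, a higher number that more compound is tolerated), share a core and differ at one end. Compound 1 `O=C(COc1cccc2ccccc12)N/N=C/c1ccc(O)cc1` gives 26.5 ug/mL. Compound 2 `C/C(=N\NC(=O)COc1cccc2ccccc12)c1ccc(O)cc1` gives 68.8 ug/mL, and compound 3 `C/C(=N\NC(=O)COc1cccc2ccccc12)c1ccc(Cl)cc1` gives 4.07 ug/mL. Compound 1 therefore stands second highest of the three: compound 2 sits above it, beyond the scatter, while compound 3 sits well below it, also beyond the scatter.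

Compound 4 `O=C(COc1cccc2ccccc12)N/N=C/c1ccccc1` is not yet measured in this assay. It arises from compound 1 by a single change, (hydrogen in place of hydroxy on an aromatic carbon). Among the measured compounds shown here, the only measured step that touches the same place is a 17-fold lower number from compound 2 to compound 3 (1.23 log units; beyond the scatter), where a chloro group took the place of the hydroxy group. For the measured compounds named here, no measured pair shows hydroxy giving way to plain hydrogen, so that step is only a loose guide: it shows that losing the hydroxy group at this aromatic carbon can lower the tolerated concentration, but it does not show what hydrogen alone does.

Compound 4 is therefore expected to come out somewhat lower than compound 1, by an estimated 1.8-fold lower number from compound 1 to compound 4 (0.25 log units; within the scatter). The estimate for compound 4 in this assay is 15 ug/mL, with a likely range from 5 ug/mL to 40 ug/mL.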

Compound 4, half-maximal cytotoxic concentration: >= 96.6 ug/mL
Compound 4: a limit, no number (the forecaster's own chance of this, stated with the estimate: 5%); middle value at least 6.4-fold (0.80 log units) away from the limit.
By their numbers in this assay, from the lowest: compound 3; then compound 1; then compound 2. At a limit, above all of these: compound 4.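

In this assay, the reading for compound 4, >= 96.6 ug/mL, is a limit of the assay and not a number: the limit of >= 96.6 ug/mL in this assay, at which 1 of the 4 values shown sits. Even so, the change from the 4-hydroxyphenyl group to phenyl can be read in its direction, giving an at least 3.6-fold higher number from compound 1 to compound 4 (0.56 log units; beyond the scatter), so taking away the hydroxy group at this aromatic carbon, para to a large group, does not by itself lower the number in this pair. Set beside a 17-fold lower number from compound 2 to compound 3 (1.23 log units; beyond the scatter), this shows that the same position can move the number either way depending on what enters, hydrogen in one pair and chloro in the other, although the two pairs start from different compounds.

On these data alone, only hydrogen and chloro have taken the place of hydroxy here, each in one pair, so it remains open where an amine, a methoxy group or a carboxylic acid at this carbon would fall. Also open, as far as these compounds go, are how far compound 4 lies past its limit and whether chloro on the core of compound 1 would bring the same kind of drop seen in the other pair.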